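The compounds below may be only part of what the source reports. "The series", "measured", "known", "first", "only" and "open" are said of these compounds alone.

Measured compounds:
compound 1 `CN(c1ccc(Oc2ncnc3sccc23)cc1)c1nccc(N2CCCCC2)n1`; in a functional assay on MDA-MB-231 cells (Homo sapiens) for inhibition, read by MTT assay, with a stated time of 72 h, tested at 20 uM (on this read-out lower numbers stand for less inhibition and higher numbers for more inhibition at the one concentration tested (going by the name of the read-out)), compound 1 gives 29.3%
compound 2 `c1cc(N2CCCCC2)nc(Nc2ccc(Oc3ncnc4sccc34)cc2)n1`; compound 2 gives 40.4%
compound 3 `c1cc(N2CCCCC2)nc(Nc2ccc(Oc3ncnc4ccsc34)cc2)n1`; compound 3 gives 45.7%

Compound 2 stands second highest of the three numbers in this assay. Its nearest neighbour is compound 3, and the step of a number 5.3 percentage points higher from compound 2 to compound 3 (within the scatter) stays within the scatter, so no order between the two can be read. Compound 1 lies furthest away, with a number 11.1 percentage points higher from compound 1 to compound 2 (beyond the scatter).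

Compound 4 `c1ccc2c(c1)CCN2c1ccnc(Nc2ccc(Oc3ncnc4sccc34)cc2)n1` is not yet measured. It differs from compound 2 in one place: 2,3-dihydro-1H-indol-1-yl in place of piperidin-1-yl on an aromatic carbon. Neither measured step touches this part of the molecule. The step from compound 1 to compound 2 exchanges hydrogen for methyl on a nitrogen on an aromatic ring, and the step from compound 2 to compound 3 exchanges the group on the aromatic oxygen. Within the data shown here, no measured step covers an exchange of the piperidin-1-yl group, so the expectation for compound 4 rests on compound 2 alone and carries wide uncertainty. Compound 4 is therefore expected to show a number 1.6 percentage points higher from compound 2 to compound 4 (within the scatter), that is, no change beyond the scatter. Compound 4 is estimated at 42%, in the range 22% to 62%.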

Compound 4, a percentage reported as inhibition, at one concentration (the size of the read-out at that concentration, not a potency): 9.95%
Beside the measured number, compound 4's estimate is 32.1 percentage points above it; the measured number lies below the stated range.
By their numbers in this assay, from the lowest: compound 4; then compound 1; then compounds 2 and 3 (each within the scatter of the next).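

Compounds 1, 2 and 3 all carry piperidin-1-yl, so they said nothing about this aromatic carbon next to the ring nitrogen. In this assay, exchanging that group for 2,3-dihydro-1H-indol-1-yl gives a number 30.5 percentage points lower from compound 2 to compound 4 (beyond the scatter), which shows that the read-out at this one concentration depends strongly on the group held at this position. The data shown offer no measurement that accounts for this loss of inhibition.

The compounds shown leave open which feature of the entering group goes with the loss, and whether a morpholin-4-yl ring or an open-chain dimethylamino group at this carbon would stay close to compound 2 or fall toward compound 4. They also leave open whether the same exchange would have a similar effect on the core of compound 3.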